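Urea aryl substitution in the shared core series

The source may hold more compounds than are shown below. What is called first, only, known or untested is meant among the compounds shown, and "the series" means these compounds.

Measured so far:
compound 1 `COc1cc(-c2nn(-c3cccc(NC(=O)Nc4ccc(Cl)c(Cl)c4)c3)cc2-c2ccncc2)ccc1Cl` — 811 nM
compound 2 `COc1cc(-c2nn(-c3cccc(NC(=O)Nc4cccc(C(F)(F)F)c4)c3)cc2-c2ccncc2)ccc1Cl` — 714 nM

In a functional assay on NCI-H522 cells (Homo sapiens) for inhibition, read by sulforhodamine B assay, with a stated time of 48 h (a lower number here means a stronger inhibitor of growth, a higher number a weaker inhibitor of growth), compound 2 gives 714 nM, the lowest of the two numbers at hand; the nearest is compound 1, and the step of a 1.1-fold lower number from compound 1 to compound 2 (0.06 log units; within the scatter) lies within the scatter, so the two compounds are not separated. Among the compounds with values here, the only measured step thus concerns the aryl group on the amide-type nitrogen and shows no effect beyond the scatter.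

Compound 3 `COc1cc(-c2nn(-c3cccc(NC(=O)Nc4ccc(Cl)c(C(F)(F)F)c4)c3)cc2-c2ccncc2)ccc1Cl` differs from compound 2 by chloro in place of hydrogen on an aromatic carbon. Within the data shown here, no measured step bears on this exact change; the one available comparison, compound 1 to compound 2, swapped the whole aryl group and stayed within the scatter, so a small change is expected here too, with no direction beyond the scatter. Compound 3 is therefore estimated at 650 nM (range 300 nM to 1400 nM), an expected step of a 1.1-fold lower number from compound 2 to compound 3 (0.04 log units; within the scatter).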

Compound 3, concentration for 50% growth inhibition: 1140 nM
Estimate against measurement, compound 3: 1.8-fold (0.24 log units) below, within the range that was stated.
By their numbers in this assay, from the lowest: compounds 2, 1 and 3 (each within the scatter of the next).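

In this assay, chloro in place of hydrogen on the 3-(trifluoromethyl)phenyl group, ortho to the trifluoromethyl group and para to a large group, gives a 1.6-fold higher number from compound 2 to compound 3 (0.20 log units; within the scatter), so this position accepts chloro without a step beyond the scatter. The second new comparison, trifluoromethyl in place of chloro on an aromatic carbon, gives a 1.4-fold higher number from compound 1 to compound 3 (0.15 log units; within the scatter), which also leaves the two compounds unseparated, so all three urea aryl groups remain within the scatter of one another. No measurement at hand accounts for these small differences.

From the compounds shown here alone, whether an amine or a carboxylic acid on this aryl group would produce a step beyond the scatter remains open. The compounds shown vary only the aryl group on the urea, so the effect of changes in the shared core also remains open.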